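A few compounds are considered here, and "the series" means these few. Any claim that something is new, unique, unknown or untested is made for them only; others in the source may bear on it.

Of the compounds shown here, three built on one shared core have been measured in a functional assay for agonist activity at G protein-coupled receptor 88 (Homo sapiens), read by HTRF and cAMP accumulation; on this read-out higher numbers stand for an effect only at larger amounts of compound and lower numbers for an effect already at smaller amounts. Compound 1 `CC[C@H](C)[C@@H](CN(C(=O)[C@@H]1C[C@H]1c1ccccc1)c1ccc(-c2ccccc2)cc1)NC(C)=O` gives 5.8 nM, the highest of the three numbers. Compound 2 `N[C@H](CN(C(=O)[C@@H]1C[C@H]1c1ccccc1)c1ccc(-c2ccccc2)cc1)C1CCCCC1` gives 0.66 nM, and compound 3 `CO[C@H](C)[C@H](N)CN(C(=O)[C@@H]1C[C@H]1c1ccccc1)c1ccc(-c2ccccc2)cc1` gives 0.68 nM. Both of these carry a free amine where compound 1 carries an acetamide, and both steps away from compound 1 are of similar size: an 8.8-fold lower number from compound 1 to compound 2 (0.94 log units; beyond the scatter) and an 8.5-fold lower number from compound 1 to compound 3 (0.93 log units; beyond the scatter). Between the two amines, the exchange of cyclohexyl for 1-methoxyethyl makes no difference worth noting: a 1.0-fold higher number from compound 2 to compound 3 (0.01 log units; within the scatter).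

Compound 4 `CC(C)(N)CN(C(=O)[C@@H]1C[C@H]1c1ccccc1)c1ccc(-c2ccccc2)cc1` has not yet been measured. It differs from compound 1 in one place: 1-amino-1-methylethyl in place of 1-acetamido-2-methylbutyl on a saturated chain carbon bound to an amide-type nitrogen. Like compound 2 and compound 3, it thus replaces the acetamide with a free amine, which is the change that gave the two large steps already seen. Unlike them, the carbon bearing that amine holds two methyl groups and no stereocentre, and no measured compound shows this arrangement, so the size of the step is less certain than its direction. On the strength of the steps to compound 2 and compound 3, a lower number is expected, and the expected step is a 4.8-fold lower number from compound 1 to compound 4 (0.68 log units; beyond the scatter). Compound 4 is estimated at 1.2 nM, with a range from 0.4 nM to 4 nM.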

Compound 4, half-maximal effective concentration: 1.4 nM
Estimate against measurement, compound 4: 1.2-fold (0.07 log units) below; low and high end bracket the measured number.
By their numbers in this assay, from the lowest: compounds 2 and 3 (each within the scatter of the next); then compound 4; then compound 1.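

Even the small 1-amino-1-methylethyl group, with its four heavy atoms and no defined stereocentre, gives a 4.1-fold lower number from compound 1 to compound 4 (0.62 log units; beyond the scatter), so neither a cyclohexyl or 1-methoxyethyl group nor a defined stereocentre on the amine-bearing carbon is required for a number clearly under that of compound 1 in this assay. The larger amine-bearing groups still hold a small edge, as the change gives a 2.1-fold higher number from compound 2 to compound 4 (0.33 log units; beyond the scatter) and a 2.1-fold higher number from compound 3 to compound 4 (0.31 log units; beyond the scatter), both steps lying only just beyond the usual scatter, so most of the gain over compound 1 remains with the smallest group shown here. No measured evidence is available to explain either the gain or the small loss.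

Every step from compound 1 changes the acetamide and the carbon framework together, so the compounds shown cannot say how much belongs to the free amine alone; 1-amino-2-methylbutyl, which would keep the framework of compound 1, would separate the two. For the compounds shown here, it also remains open whether the amine itself must be free and primary, since no compound here carries a hydroxyl or a dimethylamino group at this place.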